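This account rests on a few compounds, and the source may have more. Where it says the series, first, only, none or still open, it means among the compounds named here.

Compound 2 `O=c1oc2cccnc2n1CN1CCN(c2ccccc2)CC1` and compound 1 `O=c1oc2cccnc2n1CN1CCN(c2cccc(C(F)(F)F)c2)CC1` share one core and differ in a single place: trifluoromethyl in place of hydrogen on an aromatic carbon. In a functional assay on the whole organism with Mus musculus as the target (a higher number here means that more compound is needed for the effect, a lower number that less compound is needed), compound 2 gives 5.9 mg/kg, and compound 1 gives 3.6 mg/kg, which amounts to a 1.6-fold lower number from compound 2 to compound 1 (0.21 log units; within the scatter). Compound 3 `O=c1oc2cccnc2n1CCCN1CCN(c2ccccc2)CC1` is built on another core, and the difference between the two cores is not broken down here; in this assay compound 3 gives 15.5 mg/kg, the highest of the three numbers. Compound 4 `O=c1oc2cccnc2n1CCCN1CCN(c2cccc(C(F)(F)F)c2)CC1` has not yet been measured and stands to compound 3 exactly as compound 1 stands to compound 2: trifluoromethyl in place of hydrogen on an aromatic carbon. Since it is the same change at the same place, the step is expected to be of similar size, a 1.6-fold lower number from compound 3 to compound 4 (0.19 log units; within the scatter), because the earlier instance gave a 1.6-fold lower number from compound 2 to compound 1 (0.21 log units; within the scatter). On that basis compound 4 is expected to give about 10 mg/kg in this assay, most likely between 5 mg/kg and 20 mg/kg.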

Compound 4, dose for half-maximal effect: 22 mg/kg
Beside the measured number, compound 4's estimate is 2.2-fold (0.34 log units) below it; the whole stated range lies below it.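

In this assay, trifluoromethyl in place of hydrogen on an aromatic carbon gives a 1.4-fold higher number from compound 3 to compound 4 (0.15 log units; within the scatter). On neither core does the change give a step that stands clear of the scatter, and the two steps cannot be told apart: the same change on two cores in this assay, a 1.6-fold lower number (0.21 log units; within the scatter) from compound 2 to compound 1 and a 1.4-fold higher number (0.15 log units; within the scatter) from compound 3 to compound 4, 2.3-fold (0.37 log units) apart, within the scatter of two such steps This gives no sign that the core alters what the change does, but two pairs with steps this small do not show that the change acts alike on both cores, or that it moves the number on either.

The compounds shown leave open whether a chlorine atom or a methoxy group at that place would give a step beyond the scatter on either core. They also leave open how the change behaves with a longer chain.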